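A few compounds are considered here, and "the series" means these few. Any claim that something is new, unique, unknown or untested is made for them only; others in the source may bear on it.

Measured in an ADME assay on HepG2 cells (Homo sapiens) for cytotoxicity, with a stated time of 72 h; a lower number here means that less compound is needed, a higher number that more compound is needed for the effect:
- compound 1 `Cc1cc(NC(=O)Nc2ccc(F)cc2)c2ccccc2n1`: > 25000 nM
- compound 2 `Cc1cc(NC(=O)Nc2ccc(C(N)=O)cc2)c2ccccc2n1`: > 25000 nM
- compound 3 `Cc1cc(NC(=O)Nc2ccc(O)cc2)c2ccccc2n1`: > 25000 nM

Each of these three entries is a limit of the assay and not a number. In this assay compound 3 thus has only the limit > 25000 nM, and the other two compounds stand at the same limit. Compound 4 `Cc1cc(NC(=O)Nc2ccc(OC(F)(F)F)cc2)c2ccccc2n1` carries trifluoromethoxy where compound 3 carries hydroxy: trifluoromethyl in place of hydrogen on an oxygen on an aromatic ring.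

For the measured compounds named here, two measured steps concern the same hydroxy group: a step that the two limits leave unreadable from compound 1 to compound 3 and a step that the two limits leave unreadable from compound 2 to compound 3. Neither has a size that can be read, and the series as a whole shows (the limit of > 25000 nM in this assay, at which 3 of the 3 values shown sit). Going by the values given here, no measured compound carries trifluoromethoxy, so the data give no direction for this change. No step beyond the scatter is therefore expected, and another limit is the likeliest report. The step expected is a number no higher from compound 3 to compound 4 (the limit leaves the size open), an estimate only. Compound 4 is estimated at 25000 nM, with an expected range of 10000 nM to 50000 nM.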

Compound 4, half-maximal effective concentration: 15000 nM
For compound 4 the middle estimate is 1.7-fold (0.22 log units) above the measured one; measured number inside the range.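

In this assay, trifluoromethoxy gives the only entry in the series that is a number and not a limit of the assay. At this oxygen on an aromatic ring the change reads as an at least 1.6-fold lower number from compound 3 to compound 4 (0.22 log units; that floor lies within the scatter), and the comparisons with the other two compounds read as an at least 1.6-fold lower number from compound 2 to compound 4 (0.22 log units; that floor lies within the scatter) and an at least 1.6-fold lower number from compound 1 to compound 4 (0.22 log units; that floor lies within the scatter). As far as these compounds go, each of these is only a floor, so the true sizes stay open and no change beyond the scatter is established, the steps among the three earlier compounds cannot be read, and most of the series still rests at one limit: the limit of > 25000 nM in this assay, at which 3 of the 4 values shown sit.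

The compounds shown leave open whether an amine or a carboxylic acid in place of trifluoromethoxy would also give a number in this assay. They also leave open whether a longer chain on the same oxygen would do so.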